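The compounds below may be only part of what the source reports. "The series", "measured", "known", "first", "only" and "open" are said of these compounds alone.

Compounds built on the core of compound 1 `CCC1(Cc2ccccc2)OS(=O)(=O)C=C1OCC(=O)OC` are compared in an ADME assay on HEL cells (Homo sapiens) for cytotoxicity, with a stated time of 3 days; a higher number here means that more compound is tolerated, a lower number that less compound is tolerated. Compound 1 gives only a limit, > 200000 nM, as recorded under (the limit of > 200000 nM in this assay, at which 1 of the 3 values shown sits). Compound 2 `CCC1(Cc2ccccc2)OS(=O)(=O)C=C1OCc1cccc(Cl)c1` gives 50000 nM, and compound 3 `CCC1(Cc2ccccc2)OS(=O)(=O)C=C1OCC=C(C)C` gives 112000 nM. Among the numbers shown compound 3 stands highest; the nearest number is that of compound 2, separated by a 2.2-fold higher number from compound 2 to compound 3 (0.35 log units; beyond the scatter). Compound 4 `CCC1(Cc2ccccc2)OS(=O)(=O)C=C1OCc1ccc(C)cc1` carries 4-methylphenyl in place of 2-methylprop-1-en-1-yl on a saturated chain carbon bound to an oxygen on an unsaturated carbon, read one bond further out as 3-methylbut-2-en-1-yl to 4-methylbenzyl. The relevant measured steps are a 2.2-fold higher number from compound 2 to compound 3 (0.35 log units; beyond the scatter), where replacing 3-chlorophenyl with 2-methylprop-1-en-1-yl raised the number, and an at least 4.0-fold lower number from compound 1 to compound 2 (0.60 log units; beyond the scatter), where a 3-chlorophenyl entering lowered it. A 4-methylphenyl entering compound 4 is therefore expected to move the number modestly back downward. The expected step for compound 4 is a 1.9-fold lower number from compound 3 to compound 4 (0.27 log units; within the scatter). Compound 4 is estimated at 60000 nM, within 25000 nM to 150000 nM.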

Compound 4, half-maximal cytotoxic concentration: 41500 nM
Beside the measured number, compound 4's estimate is 1.4-fold (0.16 log units) above it, within the range that was stated.
By their numbers in this assay, from the lowest: compounds 4 and 2 (each within the scatter of the next); then compound 3. At a limit, above all of these: compound 1.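

In this assay, 4-methylphenyl in place of 3-chlorophenyl gives a 1.2-fold lower number from compound 2 to compound 4 (0.08 log units; within the scatter), so these two aromatic rings are not told apart at this place. 4-Methylphenyl in place of 2-methylprop-1-en-1-yl gives a 2.7-fold lower number from compound 3 to compound 4 (0.43 log units; beyond the scatter), so both ring-bearing compounds now read lower than compound 3. Against methoxycarbonyl the step is an at least 4.8-fold lower number from compound 1 to compound 4 (0.68 log units; beyond the scatter), read from a limit: the limit of > 200000 nM in this assay, at which 1 of the 4 values shown sits.

With only two substituted aromatic rings shown, the effect of the ring cannot be separated from that of its substituent. From the compounds shown here alone, how a carboxylic acid or an amine would read at this place remains open.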